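Swapping the chlorine position on a ring-nitrogen aryl group

The source may hold more compounds than are shown below. What is called first, only, known or untested is meant among the compounds shown, and "the series" means these compounds.

Of the compounds shown here, two have been measured in an assay on HEK293 cells for inhibition of protein kinase C zeta type (Homo sapiens), read by 33P incorporation, with a stated time of 40 min, tested at 20 uM, in the presence of a further agent that is not named here; on this read-out lower numbers stand for less inhibition and higher numbers for more inhibition at the one concentration tested (going by the name of the read-out). Compound 1, `COc1ccc(C2=NN(c3cccc(Cl)c3)C(c3cccc(Cl)c3)C2)cc1`, gives 25.3% in this assay. Compound 2, `COc1ccc(C2=NN(c3ccc(Cl)cc3)C(c3ccc(Cl)cc3)C2)c(OC)c1`, carries two methoxy groups and two 4-chlorophenyl groups and gives 28.6% in this assay. Compound 1 has the lowest of the two numbers, but the gap to compound 2 lies within the usual scatter of this kind of measurement, so the two values cannot be told apart.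

Compound 3, `COc1ccc(C2=NN(c3ccc(Cl)cc3)C(c3cccc(Cl)c3)C2)cc1`, has not yet been measured. It shares every atom with compound 1, joined differently: 4-chlorophenyl in place of 3-chlorophenyl on an amine nitrogen in a ring. In plain terms, the chlorine on the aryl group at the amine nitrogen in the ring moves from the 3-position to the 4-position, while the rest of the molecule stays as in compound 1.

Among the compounds with values here, no step between two measured compounds differing in exactly one place is available, so the expectation rests only on the two numbers above, which sit close together. The step of a number 1.7 percentage points higher from compound 1 to compound 3 (within the scatter) is expected to be small and within the scatter, with no clear direction. Compound 3 is therefore expected to give about 27% in this assay, estimated to fall between 14% and 40%.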

Compound 3, a percentage reported as inhibition, at one concentration (the size of the read-out at that concentration, not a potency): 39%
Compound 3: the middle estimate sits 12 percentage points below what was measured, within the range that was stated.
By their numbers in this assay, from the lowest: compounds 1 and 2 (each within the scatter of the next); then compound 3.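

In this assay, putting 4-chlorophenyl in place of 3-chlorophenyl on the amine nitrogen in the ring gives a number 13.7 percentage points higher from compound 1 to compound 3 (beyond the scatter), a modest step. Compounds 1 and 2 differ in more than one place and sit within the scatter of each other, so they could not show that this position responds to anything; this pair shows that moving one chlorine around the same aryl ring is enough to change the inhibition read at the one concentration tested, with the atoms of the molecule unchanged. Nothing available here explains why the 4-chlorophenyl group gives the higher number, so the step stands as an observation only.

As far as these compounds go, it remains open whether the same swap would have a similar effect on the 3-chlorophenyl group on the neighbouring ring atom, and whether this step would hold up as a difference in potency rather than in inhibition at a single concentration. From the compounds shown here alone, it is also open how this nitrogen position would respond if the chlorine on the phenyl ring gave way to something quite different, such as a carboxylic acid or a dimethylamino group.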